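Salicylanilide benzyl ethers: moving from dichloro to chloro-methyl

This account rests on a few compounds, and the source may have more. Where it says the series, first, only, none or still open, it means among the compounds named here.

Measured so far in an assay on lysate for inhibition of phosphatidylcholine:ceramide cholinephosphotransferase 2 (Homo sapiens), read by HPLC, with stated times of 30 min and 2 h; a lower number here means a stronger inhibitor, a higher number a weaker inhibitor:
compound 1 `O=C(Nc1cccnc1)c1ccccc1OCc1ccccc1Cl` gives 1100 nM;
compound 2 `Cc1ccccc1COc1ccccc1C(=O)Nc1cccnc1` gives 1500 nM;
compound 3 `O=C(Nc1cccnc1)c1ccccc1OCc1c(Cl)cccc1Cl` gives 690 nM.

Compound 3 carries the lowest number of the three: against compound 2 the step of a 2.2-fold lower number from compound 2 to compound 3 (0.34 log units; beyond the scatter) is beyond the scatter, against compound 1 the step of a 1.6-fold lower number from compound 1 to compound 3 (0.20 log units; within the scatter) is not. Compound 4 `Cc1c(Cl)cccc1COc1ccccc1C(=O)Nc1cccnc1` changes (3-chloro-2-methylphenyl in place of 2,6-dichlorophenyl on a saturated chain carbon bound to an oxygen on an aromatic ring). Among the measured compounds shown here, two measured steps bear on this: swapping chloro for methyl, a 1.4-fold higher number from compound 1 to compound 2 (0.13 log units; within the scatter), stayed within the scatter, and adding a second chloro, a 1.6-fold lower number from compound 1 to compound 3 (0.20 log units; within the scatter), also stayed within it. Compound 4 keeps one chloro and one methyl, so in this assay no step beyond the scatter is expected, if anything a slightly higher number. Compound 4 is therefore estimated at 900 nM, range 450 nM to 1800 nM. The expected step is a 1.3-fold higher number from compound 3 to compound 4 (0.12 log units; within the scatter).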

Compound 4, half-maximal inhibitory concentration: 3800 nM
The estimate for compound 4 lay 4.2-fold (0.63 log units) below the measured number; measured number outside the range, above it.
By their numbers in this assay, from the lowest: compounds 3, 1 and 2 (each within the scatter of the next, the first and the last beyond it); then compound 4.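

The group at this place is not interchangeable: 3-chloro-2-methylphenyl stands apart from all three earlier groups, with a 5.5-fold higher number from compound 3 to compound 4 (0.74 log units; beyond the scatter), a 3.5-fold higher number from compound 1 to compound 4 (0.54 log units; beyond the scatter) and a 2.5-fold higher number from compound 2 to compound 4 (0.40 log units; beyond the scatter). The earlier compounds showed only small steps, and chloro in place of hydrogen on an aromatic carbon now has no single direction in this series: the same change on two cores in this assay, a 1.6-fold lower number (0.20 log units; within the scatter) from compound 1 to compound 3 and a 2.5-fold higher number (0.40 log units; beyond the scatter) from compound 2 to compound 4, 4.0-fold (0.61 log units) apart, beyond the scatter of two such steps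

Still open, going by these compounds, is whether the higher number belongs to the chloro of 3-chloro-2-methylphenyl alone or to its pairing with the methyl. Also open, on these data alone, is how an amine or a methoxy group in place of that chloro would read.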